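Swapping the aryl group on a triazole core

The source may report more compounds than this note shows. Statements on the series, on what has been measured and on what is new or still open speak of the compounds shown alone.

Compound 1 `COc1ccccc1-c1ncnn1-c1cc(OC)c(OC)c(OC)c1` carries a 2-methoxyphenyl group on its five-membered core. In a functional assay on HL-60 cells (Homo sapiens) for antiproliferative activity, read by MTT assay, with a stated time of 72 h (a higher number here means a weaker inhibitor, a lower number a stronger inhibitor), compound 1 reaches only the limit of the measurement, > 10000 nM, so no number is known for it. Compound 2 `COc1cc(-c2ncnn2-c2ccccc2)cc(OC)c1OC` also sits at a limit, > 10000 nM. Compound 3 `COc1cc(-c2ncnn2-c2ccc(Cl)c(Cl)c2)cc(OC)c1OC` again gives only a limit, > 10000 nM. The only single change among these, a step that the two limits leave unreadable from compound 2 to compound 3, therefore cannot be read for size, and the one fact shared by all three is the limit of > 10000 nM in this assay, at which 3 of the 3 values shown sit.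

Compound 4 `COc1cc(-n2ncnc2-c2ccc(Cl)c(Cl)c2)cc(OC)c1OC` differs from compound 1 by 3,4-dichlorophenyl in place of 2-methoxyphenyl on an aromatic carbon. Within the data shown here, no measured step bears directly on this change, since every value so far is a limit, and the change from phenyl to 3,4-dichlorophenyl between compound 2 and compound 3 did not lift either out of the limit. Compound 4 is therefore expected to stay near that limit, with the step that the limit leaves unreadable from compound 1 to compound 4 estimated as no more than the scatter. For compound 4 the expected value is 15000 nM, within a range from 5000 nM to 60000 nM.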

Compound 4, half-maximal inhibitory concentration: > 10000 nM
Compound 4 was reported as a limit; the forecaster's own chance of this, stated with the estimate: 80%; the middle value is on the limit's open side.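

Compound 4 also gives only a limit, > 10000 nM, so the step from compound 1 to compound 4 cannot be read for size. The compounds shown leave open how strongly any of them really acts and whether swapping these groups matters at all, as one fact covers them all: the limit of > 10000 nM in this assay, at which 4 of the 4 values shown sit.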